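Working notes: the step from compound 2 to compound 3

The compounds below may be only part of what the source reports. "The series", "measured", "known", "first", "only" and "open" are said of these compounds alone.

Measured in a functional assay on K562 cells (Homo sapiens) for antiproliferative activity, read by MTT assay; on this read-out lower numbers stand for stronger inhibition and higher numbers for weaker inhibition:
- compound 1 (`O=C(CCCCCNC(=S)NN=C(c1ccccn1)c1ccccn1)NO`) gives 2870 nM
- compound 2 (`O=C(CCCCCNC(=S)N/N=C(\c1ccccc1)c1ccccn1)NO`) gives 2140 nM

Compound 2 stands within the scatter of compound 1, so the two values cannot be separated in this assay on these data. Compound 3 (`Cc1ccccc1/C(=N/NC(=S)NCCCCCC(=O)NO)c1ccccc1`) has not yet been measured. Its difference from compound 2 is 2-methylphenyl in place of pyridin-2-yl on a carbon with a double bond to nitrogen. Within the data shown here, no measured pair shows this exchange on its own, so the data offer no direct guide to its size. With compound 1 at 2870 nM and compound 2 at 2140 nM in the same range, no shift beyond the scatter is expected, with a slight lean toward a higher number. The expected 1.3-fold higher number from compound 2 to compound 3 (0.12 log units; within the scatter) is therefore small. For compound 3 the estimated value is 2800 nM (expected range 1200 nM to 6500 nM).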

Compound 3, half-maximal inhibitory concentration: 3510 nM
Beside the measured number, compound 3's estimate is 1.3-fold (0.10 log units) below it, and the stated range covers the measured number.
By their numbers in this assay, from the lowest: compounds 2, 1 and 3 (each within the scatter of the next).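

In this assay, among these compounds, the exchange of pyridin-2-yl for 2-methylphenyl on the carbon with a double bond to nitrogen gives a 1.6-fold higher number from compound 2 to compound 3 (0.21 log units; within the scatter), the first direct reading of a change at this position, and it does not separate the two compounds. In this one pair, the ring hetero atom with its hydrogen-bond acceptor leaves and a methyl group enters in a single step, so the data cannot assign any part of the step to either change. Nothing available accounts for the size of this step.

Still open, as far as these compounds go, is whether an amine or a carboxylic acid in place of the methyl of 2-methylphenyl would move the number beyond the scatter. Also open, from the compounds shown here alone, is how a longer chain in the shared core would read in this assay.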